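This account rests on a few compounds, and the source may have more. Where it says the series, first, only, none or still open, it means among the compounds named here.

Compound 1 `ClCc1cccc(Cn2cnc3c(Cl)ncnc32)c1`: 4360 nM
Compound 2 `ClCc1cccc(Cn2cnc3c(Cl)nc(Cl)nc32)c1`: 3460 nM
Compound 3 `ClCc1ccccc1Cn1cnc2ncnc(Cl)c21`: 4670 nM

These three were tested in a functional assay on SW-620 cells (Homo sapiens) for cytotoxicity, read by sulforhodamine B assay, with a stated time of 48 h; a lower number here means a stronger inhibitor of growth, a higher number a weaker inhibitor of growth. Compound 1 and compound 2 differ by one change, (chloro in place of hydrogen on an aromatic carbon), and the step was a 1.3-fold lower number from compound 1 to compound 2 (0.10 log units; within the scatter). Compound 3 has the same atoms as compound 1 joined differently; the difference between the two cores is not broken down here. Compound 3 and compound 1 show numbers within the scatter of each other.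

Compound 4 `ClCc1ccccc1Cn1cnc2nc(Cl)nc(Cl)c21` is compound 3 with the same change, (chloro in place of hydrogen on an aromatic carbon). Going by the values given here, since the one time this change was measured it gave only a 1.3-fold lower number from compound 1 to compound 2 (0.10 log units; within the scatter), the expected step is similar, a 1.3-fold lower number from compound 3 to compound 4 (0.10 log units; within the scatter), and could equally be no change at all. The estimate for compound 4 in this assay is 3700 nM, expected to lie between 1800 nM and 7500 nM.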

Compound 4, concentration for total growth inhibition: 670 nM
The estimate for compound 4 lay 5.5-fold (0.74 log units) above the measured number; the whole stated range lies above it.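

In this assay, adding the chloro group gave a 7.0-fold lower number from compound 3 to compound 4 (0.84 log units; beyond the scatter), and this step did not match the earlier one on the other core: the same change on two cores in this assay, a 1.3-fold lower number (0.10 log units; within the scatter) from compound 1 to compound 2 and a 7.0-fold lower number (0.84 log units; beyond the scatter) from compound 3 to compound 4, 5.5-fold (0.74 log units) apart, beyond the scatter of two such steps So in these two pairs the size of the step depends on the core that carries the change, with a clear gain only on the core of compound 3. Two pairs give no general rule, and they do not show which difference between the two cores matters or why.

Going by these compounds, it stays open whether an amine or a methoxy group in that place would give a similar step on each core. On these data alone, it is also open how either core would respond if a hydroxymethyl group replaced the chloromethyl group.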